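The compounds below may be only part of what the source reports. "The series", "measured", "known", "first", "only" and "open" are said of these compounds alone.

Working notes on the series. In a functional assay on HepG2 cells (Homo sapiens) for cytotoxicity, read by MTT assay, with a stated time of 48 h (on this read-out lower numbers stand for stronger inhibition and higher numbers for weaker inhibition), three compounds with a shared core have been measured: compound 1 `Cc1ncc([N+](=O)[O-])n1CCSc1nnc(-c2ccccc2)o1` gives 17500 nM, compound 2 `Cc1ncc([N+](=O)[O-])n1CCSc1nnc(-c2ccco2)o1` gives 22600 nM, and compound 3 `Cc1ncc([N+](=O)[O-])n1CCSc1nnc(-c2ccccn2)o1` gives 20200 nM. Compound 3 cannot be separated from the other two, as the data show a 1.2-fold higher number from compound 1 to compound 3 (0.06 log units; within the scatter) and a 1.1-fold lower number from compound 2 to compound 3 (0.05 log units; within the scatter).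

The next compound is compound 4 `Cc1ncc([N+](=O)[O-])n1CCSc1nnc(-c2cccnc2)o1`, which keeps the shared core. The change is pyridin-3-yl in place of pyridin-2-yl on an aromatic carbon; in short, pyridin-3-yl in place of pyridin-2-yl on an aromatic carbon.

All three measured steps bear on this change, since each exchanges one group for another on that same aromatic carbon. Besides the two steps above, the third is a 1.3-fold higher number from compound 1 to compound 2 (0.11 log units; within the scatter). None of the three exceeds the scatter, so this place has shown no sensitivity among the groups tried so far. Within the data shown here, no measured compound carries pyridin-3-yl, so direct evidence for this group is lacking.

No step beyond the scatter is therefore expected in this assay, and no direction can be assigned. The estimated step is a 1.0-fold lower number from compound 3 to compound 4 (0.00 log units; within the scatter). For compound 4 the expected value is 20000 nM, with an estimated range of 12000 nM to 33000 nM.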

Compound 4, half-maximal inhibitory concentration: 9600 nM
The estimate for compound 4 lay 2.1-fold (0.32 log units) above the measured number; measured number below the stated range.
By their numbers in this assay, from the lowest: compounds 4, 1, 3 and 2 (each within the scatter of the next, the first and the last beyond it).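

At this aromatic carbon in this assay, the groups are no longer all equivalent: the pyridin-3-yl group gives a 2.1-fold lower number from compound 3 to compound 4 (0.32 log units; beyond the scatter) and a 2.4-fold lower number from compound 2 to compound 4 (0.37 log units; beyond the scatter), both modest steps but the first here to lie beyond the scatter. The first of these is the more informative, since pyridin-2-yl and pyridin-3-yl have the same atoms and the same counted features and differ only in how they are joined, so the attachment of the pyridine ring alone separates the two compounds, while the other step also exchanges the ring itself; the sensitivity is limited, however, as phenyl remains unresolved from pyridin-3-yl, with a 1.8-fold lower number from compound 1 to compound 4 (0.26 log units; within the scatter). No available evidence bears on why the pyridin-3-yl group departs from the pyridin-2-yl group.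

The compounds shown leave open whether pyridin-4-yl would follow pyridin-3-yl or pyridin-2-yl, and whether an amine or a carboxylic acid on the ring at this carbon would extend the step. Among these compounds, with only one compound carrying pyridin-3-yl, it also remains open whether a step of this modest size is general to this group or confined to the present shared core.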